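Replacing 3-fluorophenyl with 4-bromophenyl on the shared core

A few compounds are considered here, and "the series" means these few. Any claim that something is new, unique, unknown or untested is made for them only; others in the source may bear on it.

- Compound 1 `CNC(=O)c1ccccc1Oc1nc(Nc2ccccc2OC)ncc1Br`: > 50000 nM (a limit)
- Compound 2 `Cc1cccc(Nc2ncc(Br)c(Oc3cccc(F)c3)n2)c1`: 15500 nM

Within the data shown here, in a functional assay on HL-60 cells (Homo sapiens) for antiproliferative activity, read by MTT assay, with a stated time of 24 h (a higher number here means a weaker inhibitor, a lower number a stronger inhibitor), compound 2 gives 15500 nM, the only actual number so far. Compound 1 is reported as > 50000 nM, which is a limit and not a number.

Compound 3 `Cc1cccc(Nc2ncc(Br)c(Oc3ccc(Br)cc3)n2)c1` keeps the core of compound 2 and differs in one place: 4-bromophenyl in place of 3-fluorophenyl on an oxygen on an aromatic ring. Among the measured compounds shown here, no measured pair shows what such a swap does, so no change beyond the usual scatter is expected in this assay. The expected result is a 1.2-fold lower number from compound 2 to compound 3 (0.08 log units; within the scatter). For compound 3 the estimated value is 13000 nM, with an expected range of 4500 nM to 40000 nM.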

Compound 3, half-maximal inhibitory concentration: 14700 nM
Compound 3: middle estimate off by 1.1-fold (0.05 log units), on the low side; measured number inside the range.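

Swapping 3-fluorophenyl for 4-bromophenyl on an oxygen on an aromatic ring gives a 1.1-fold lower number from compound 2 to compound 3 (0.02 log units; within the scatter) in this assay and so shows no readable change at this position. Among these compounds, this is the first comparison of compounds that differ in one place, and it shows that these two rings cannot be told apart here. Nothing measured here explains why the two compounds give such similar numbers. Still open, from the compounds shown here alone, is whether an amine or a carboxylic acid on this ring, or a longer chain in its place, would shift the number.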